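Amino for Hydrogen on a Coumarin-Furoxan Hybrid

This account rests on a few compounds, and the source may have more. Where it says the series, first, only, none or still open, it means among the compounds named here.

Measured so far in a functional assay on A549 cells (Homo sapiens) for inhibition, read by MTT assay, with a stated time of 48 h; a higher number here means a weaker inhibitor, a lower number a stronger inhibitor:
- compound 1 `COc1cc2ccc(=O)oc2cc1OCCOc1no[n+]([O-])c1S(=O)(=O)c1ccccc1` gives 7240 nM
- compound 2 `COc1cc2cc(NC(C)=O)c(=O)oc2cc1OCCCOc1no[n+]([O-])c1S(=O)(=O)c1ccccc1` gives 9810 nM
- compound 3 `COc1cc2cc(NC(C)=O)c(=O)oc2cc1OCCCCOc1no[n+]([O-])c1S(=O)(=O)c1ccccc1` gives 7190 nM

The three numbers lie within the scatter of each other, so compound 1 stands among them with no gap that can be read as a difference. Compound 4 `COc1cc2cc(N)c(=O)oc2cc1OCCOc1no[n+]([O-])c1S(=O)(=O)c1ccccc1` is still unmeasured; it differs from compound 1 by amino in place of hydrogen on an aromatic carbon, on an aromatic carbon of a six-membered aromatic ring with one oxygen, two atoms from the ring oxygen. Among the measured compounds shown here, no step between measured compounds exists that could show what this change does. Because compound 1 gives 7240 nM and its neighbours sit within the scatter, compound 4 is expected to stay close, with the step of a 1.0-fold lower number from compound 1 to compound 4 (0.01 log units; within the scatter) expected to fall inside the scatter. The estimate for compound 4 in this assay is 7000 nM, within 3000 nM to 17000 nM.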

Compound 4, half-maximal inhibitory concentration: 5910 nM
For compound 4 the middle estimate is 1.2-fold (0.07 log units) above the measured one; the measured number falls inside the stated range.
By their numbers in this assay, from the lowest: compounds 4, 3, 1 and 2 (each within the scatter of the next).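

In this assay, among the compounds shown here, amino in place of hydrogen on an aromatic carbon, two atoms from the ring oxygen, gives a 1.2-fold lower number from compound 1 to compound 4 (0.09 log units; within the scatter) and so provides the first step that isolates a single place. On the core of compound 1, this change at this position produces no difference that can be read. Nothing at hand bears on the reason for this result.

The compounds shown leave open what a hydroxyl or a carboxylic acid on the same carbon would give. They also leave open whether amino gives a similar step with a longer chain.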